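The source may report more compounds than this note shows. Statements on the series, on what has been measured and on what is new or still open speak of the compounds shown alone.

Three compounds that share one core and differ only in the aromatic group attached to an amine nitrogen in a ring have been measured in an assay on CHO cells for displacement of a labelled ligand from adenosine receptor A3 (Homo sapiens), read by scintillation counting, with a stated time of 120 min, tested at 10 uM; on this read-out lower numbers stand for less inhibition and higher numbers for more inhibition at the one concentration tested (going by the name of the read-out). Compound 1, `Nc1scc(CN2CCN(c3ccc(Cl)cc3Cl)CC2)c1C(=O)c1ccc(Cl)cc1`, gives 0%. Compound 2, `Nc1scc(CN2CCN(c3cccc(C(F)(F)F)c3)CC2)c1C(=O)c1ccc(Cl)cc1`, gives 0%. Compound 3, `Nc1scc(CN2CCN(c3ccc(F)c(F)c3)CC2)c1C(=O)c1ccc(Cl)cc1`, gives 1%. On the bare numbers compound 3 sits at the top of the three, yet the gaps, a number 1 percentage points higher from compound 1 to compound 3 (within the scatter) and a number 1 percentage points higher from compound 2 to compound 3 (within the scatter), are both within the scatter, as is no change at the digits printed from compound 1 to compound 2 (within the scatter), so the three results cannot be told apart: none of these aromatic groups produces inhibition worth noting at the concentration tested.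

Compound 4, `Nc1scc(CN2CCN(c3cccc(F)c3F)CC2)c1C(=O)c1ccc(Cl)cc1`, is the next step. It differs from compound 3 only in its difluorophenyl group: 2,3-difluorophenyl in place of 3,4-difluorophenyl on an amine nitrogen in a ring. Every measured step that exchanged one aromatic group on this ring nitrogen for another, namely no change at the digits printed from compound 1 to compound 2 (within the scatter), a number 1 percentage points higher from compound 1 to compound 3 (within the scatter) and a number 1 percentage points higher from compound 2 to compound 3 (within the scatter), left the reading unchanged within the scatter, and none of the three groups raised it off the floor. Nothing in these data suggests that swapping one difluorophenyl for another should do what changing the whole group did not. The expected step of no change at the digits printed from compound 3 to compound 4 (within the scatter) is therefore none beyond the scatter. Compound 4 is expected to give 1%, with a range from 0% to 10%.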

Compound 4, a percentage reported as inhibition, at one concentration (the size of the read-out at that concentration, not a potency): 0%
For compound 4 the middle estimate is 1 percentage points above the measured one, within the range that was stated.
By their numbers in this assay, from the lowest: compounds 1, 2, 4 and 3 (each within the scatter of the next).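

Rearranging the two fluorines, with 2,3-difluorophenyl in place of 3,4-difluorophenyl and the same atoms joined differently, gives a number 1 percentage points lower from compound 3 to compound 4 (within the scatter) in this assay, and the comparisons with the earlier groups, no change at the digits printed from compound 2 to compound 4 (within the scatter) and no change at the digits printed from compound 1 to compound 4 (within the scatter), are equally flat. This position on the ring nitrogen has now been varied both by exchanging the whole aromatic group and by only rearranging its atoms, and all four compounds remain indistinguishable, with none of them going against this picture and none lifting the reading off the floor at the one concentration tested. No measurement at hand offers an explanation for this result.

From the compounds shown here alone, all four compounds carry an aromatic group on this nitrogen, so it remains open whether a cyclohexyl ring, a simple methyl or a phenyl ring bearing a methoxy group or a nitrile would read any differently here. The rest of the shared core is also the same throughout, which leaves unknown what a change there, such as an amide in place of its free amine, would do.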